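The compounds below may be only part of what the source reports. "The series", "measured", "known", "first", "only" and "open" are said of these compounds alone.

Three compounds share one core and differ only in the group on an oxygen on a saturated carbon. In a functional assay with Homo sapiens as the target (a higher number here means a weaker inhibitor, a lower number a stronger inhibitor), compound 1 `CC(C)[C@H](NC(=O)COc1cccc2ccccc12)C(=O)N[C@@H](CC(=O)O)C(=O)COc1ccc(-c2ccccc2)cc1` gives 38700 nM, compound 2 `CC(C)[C@H](NC(=O)COc1cccc2ccccc12)C(=O)N[C@@H](CC(=O)O)C(=O)COc1ccccc1F` gives 15700 nM, and compound 3 `CC(C)[C@H](NC(=O)COc1cccc2ccccc12)C(=O)N[C@@H](CC(=O)O)C(=O)COc1cc(F)ccc1F` gives 19700 nM. Compound 3 cannot be told apart from either of the others, since the data show a 1.3-fold higher number from compound 2 to compound 3 (0.10 log units; within the scatter) and a 2.0-fold lower number from compound 1 to compound 3 (0.29 log units; within the scatter). Only a 2.5-fold lower number from compound 1 to compound 2 (0.39 log units; beyond the scatter) clears the scatter, and it is a modest step that swaps a much larger group.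

Compound 4 `CC(C)[C@H](NC(=O)COc1cccc2ccccc12)C(=O)N[C@@H](CC(=O)O)C(=O)COc1ccc(F)c(F)c1F` has not yet been measured. It carries 2,3,4-trifluorophenyl in place of 2,5-difluorophenyl on an oxygen on a saturated carbon. The closest guide is the change of hydrogen to fluoro on an aromatic carbon, which gave a 1.3-fold higher number from compound 2 to compound 3 (0.10 log units; within the scatter). Within the data shown here, no measured pair tests a rearrangement of the fluorines like this one, so that guide is only partial. Even the large swap moved this assay only modestly, so no shift beyond the scatter is expected here. The estimated change is a 1.1-fold lower number from compound 3 to compound 4 (0.04 log units; within the scatter). For compound 4 the expected value is 18000 nM, with an estimated range of 9000 nM to 36000 nM.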

Compound 4, half-maximal inhibitory concentration: 20600 nM
For compound 4 the middle estimate is 1.1-fold (0.06 log units) below the measured one, and the stated range covers the measured number.
By their numbers in this assay, from the lowest: compounds 2, 3, 4 and 1 (each within the scatter of the next, the first and the last beyond it).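

In this assay the 2,3,4-trifluorophenyl group in place of 2,5-difluorophenyl gives a 1.0-fold higher number from compound 3 to compound 4 (0.02 log units; within the scatter) and so adds a new fluorine pattern on the group attached to the oxygen, yet the two compounds cannot be told apart. Among these compounds, compound 4 also stands within the scatter of the other two compounds, with a 1.3-fold higher number from compound 2 to compound 4 (0.12 log units; within the scatter) against the 2-fluorophenyl group and a 1.9-fold lower number from compound 1 to compound 4 (0.27 log units; within the scatter) against the much larger 4-phenylphenyl group, so the one step beyond the scatter in this set remains the one between compound 1 and compound 2. The data on hand offer no independent measurement that could explain why these groups read so alike.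

Among the compounds shown here, all the groups at this position so far are phenyl rings carrying fluorine or a second phenyl, so it remains open how a phenyl ring with no fluorine, or one carrying an amine or a carboxylic acid, would read in this assay at this place. The compounds shown also leave open whether any change at this position can bring the number far from the level of these four, since every one shares the same core.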